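The source may hold more compounds than are shown below. What is called first, only, known or untested is meant among the compounds shown, and "the series" means these compounds.

Measured so far in a functional assay on HEK293 cells (Homo sapiens) for cytotoxicity; a lower number here means that less compound is tolerated, a higher number that more compound is tolerated:
Compound 1 `COc1ccc([C@H]2CC(=O)N(c3cc(N)cc(N)c3)C2)cc1OC1CCCC1`: > 10000 nM
Compound 2 `COc1ccc([C@H]2CC(=O)N(c3cc(N)cc(F)c3)C2)cc1OC1CCCC1`: > 10000 nM

Compound 2 gives > 10000 nM, which is a limit of the assay and not a number. Compound 1 gives > 10000 nM, which is also a limit. Both results therefore sit at the same point: the limit of > 10000 nM in this assay, at which 2 of the 2 values shown sit.

Compound 3 `COc1ccc([C@H]2CC(=O)N(c3ccccc3C)C2)cc1OC1CCCC1` keeps the shared core but changes the group on the amide-type nitrogen in a ring, with 2-methylphenyl in place of 3-amino-5-fluorophenyl on an amide-type nitrogen in a ring.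

Going by the values given here, only one measured step bears on this, and it involves the same aromatic group, with fluoro in place of amino on an aromatic carbon. It is a step that the two limits leave unreadable from compound 1 to compound 2, so it offers no size to carry over. With only that to go on, no step beyond the scatter is expected in this assay, and no direction can be given. The estimated change is a step that the limit leaves unreadable from compound 2 to compound 3. Compound 3 is expected at about 15000 nM. The expected range for compound 3 runs from 6000 nM to 40000 nM, and the result may well be reported only as a limit.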

Compound 3, half-maximal cytotoxic concentration: > 10000 nM
Compound 3: a limit, no number; the forecaster's own chance of this, stated with the estimate: 85%; the middle value lies beyond the limit too.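

In this assay, no size can be read for any step among compound 1, compound 2 and compound 3, because all three results are limits and not numbers: the limit of > 10000 nM in this assay, at which 3 of the 3 values shown sit.

Going by these compounds, what stays open is the actual concentration at which each compound becomes cytotoxic, and whether the different groups on the amide-type nitrogen in a ring change it at all.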